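Trifluoromethoxy in Place of Fluoro: Expectation for Compound 4

A few compounds are considered here, and "the series" means these few. Any claim that something is new, unique, unknown or untested is made for them only; others in the source may bear on it.

Compound 1 `Nc1ccc(-c2ccc3c(c2)oc(=O)n3Cc2ccc(F)cc2)cn1` gives 16500 nM in a functional assay on HCT-116 cells (Homo sapiens) for inhibition, read by MTT assay, with a stated time of 72 h; on this read-out lower numbers stand for stronger inhibition and higher numbers for weaker inhibition.
Compound 2 `O=c1oc2cc(-c3cnc4[nH]ccc4c3)ccc2n1Cc1ccc(F)cc1` gives 5990 nM in this assay.
Compound 3 `O=c1oc2cc(-c3cnc4[nH]ccc4c3)ccc2n1Cc1cccc(F)c1` gives 5920 nM in this assay.

Among these three numbers compound 3 has the lowest, but its number and that of compound 2 sit within the usual scatter of each other, so no order between the two can be claimed; only compound 1 stands apart, with a 2.8-fold lower number from compound 1 to compound 2 (0.44 log units; beyond the scatter).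

Compound 4 `O=c1oc2cc(-c3cnc4[nH]ccc4c3)ccc2n1Cc1cccc(OC(F)(F)F)c1` has not been measured. It differs from compound 3 in one place: trifluoromethoxy in place of fluoro on an aromatic carbon.

No measured step swaps fluoro for trifluoromethoxy, so nothing shown bears directly on this change. Among the measured compounds shown here, the one step that touched the same ring, a 1.0-fold lower number from compound 2 to compound 3 (0.01 log units; within the scatter), moved the fluoro from one position to another and left the number essentially unchanged, which hints that this ring tolerates small alterations, though a larger group is a different matter. With that, the expected outcome is a step of a 1.1-fold lower number from compound 3 to compound 4 (0.03 log units; within the scatter), a number for compound 4 close to that of compound 3 and within the scatter in either direction.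

The estimate for compound 4 is therefore 5500 nM, with a range from 2000 nM to 15000 nM.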

Compound 4, half-maximal inhibitory concentration: 7060 nM
The estimate for compound 4 lay 1.3-fold (0.11 log units) below the measured number; the range from low to high includes it.
By their numbers in this assay, from the lowest: compounds 3, 2 and 4 (each within the scatter of the next); then compound 1.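

Placing trifluoromethoxy on this aromatic carbon instead of fluoro gives a 1.2-fold higher number from compound 3 to compound 4 (0.08 log units; within the scatter) in this assay and thus leaves compound 3 and compound 4 indistinguishable on this read-out. The earlier step on this ring only moved a fluoro from one place to another, so it could not show what a bigger group would do; here trifluoromethoxy, including a hydrogen-bond acceptor, takes the place of a single fluorine atom, and the two numbers still cannot be told apart. No measurement shown offers an explanation for this result.

Every compound shown carries fluorine in its substituent on this ring, so it remains open how the number would read with a plain hydrogen there, or with an amine or a carboxylic acid in the same place. From the compounds shown here alone, it also remains open whether a much longer chain at this carbon would still sit within the scatter of compound 3, since a single larger group cannot show how far this tolerance extends.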